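The source may hold more compounds than are shown below. What is called first, only, known or untested is meant among the compounds shown, and "the series" means these compounds.

Measured compounds in a functional assay on NCI-H460 cells (Homo sapiens) for inhibition, read by MTT assay, with a stated time of 72 h; a lower number here means a stronger inhibitor, a higher number a weaker inhibitor: compound 1 `COc1cc2c(Oc3ccc(NC(=O)c4nn(-c5ccccc5)c(=O)cc4C)cc3F)ccnc2cc1OCCCN1CCCC1` gives 460 nM; compound 2 `COc1cc2c(Oc3ccc(NC(=O)c4nn(-c5ccccc5C)c(=O)cc4C)cc3F)ccnc2cc1OCCCN1CCCC1` gives 1590 nM; compound 3 `COc1cc2c(Oc3ccc(NC(=O)c4nn(-c5ccccc5OC(F)(F)F)c(=O)cc4C)cc3F)ccnc2cc1OCCCN1CCCC1` gives 210 nM.

Compound 3 holds the lowest number of the three, with compound 1 nearest and compound 2 furthest. Compound 4 `COc1ccc(-n2nc(C(=O)Nc3ccc(Oc4ccnc5cc(OCCCN6CCCC6)c(OC)cc45)c(F)c3)c(C)cc2=O)cc1` differs from compound 3 by 4-methoxyphenyl in place of 2-(trifluoromethoxy)phenyl on an aromatic nitrogen. Among the measured compounds shown here, no measured step swaps one substituted phenyl for another at this nitrogen, so the closest guides are the changes on that ring: a 2.2-fold lower number from compound 1 to compound 3 (0.34 log units; beyond the scatter) and a 3.5-fold higher number from compound 1 to compound 2 (0.54 log units; beyond the scatter), with a 7.6-fold lower number from compound 2 to compound 3 (0.88 log units; beyond the scatter) spanning both. Losing the trifluoromethoxy is thus expected to cost something, while a methoxy at a new position has no precedent here. Compound 4 is therefore expected to land near compound 1, a step of a 1.7-fold higher number from compound 3 to compound 4 (0.22 log units; within the scatter), giving an estimated 350 nM with a range of 120 nM to 1000 nM.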

Compound 4, half-maximal inhibitory concentration: 3610 nM
Compound 4: the middle estimate sits 10-fold (1.01 log units) below what was measured; the measured number lies above the stated range.
By their numbers in this assay, from the lowest: compound 3; then compound 1; then compound 2; then compound 4.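

In this assay, among the compounds shown here, this nitrogen substituent proves far more sensitive than the earlier compounds showed: 4-methoxyphenyl in place of 2-(trifluoromethoxy)phenyl gives a 17-fold higher number from compound 3 to compound 4 (1.24 log units; beyond the scatter) and is the largest step in the set. Methoxy added to the plain phenyl gives a 7.8-fold higher number from compound 1 to compound 4 (0.89 log units; beyond the scatter) and, against 2-methylphenyl, the same group gives a 2.3-fold higher number from compound 2 to compound 4 (0.36 log units; beyond the scatter) so that, of the three substituted phenyls, only the one in compound 3 has a lower number than plain phenyl. Nothing given here explains these steps.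

The compounds shown leave open whether the substituent itself or its place on the phenyl drives them. As far as these compounds go, how an amine or a carboxylic acid on that ring would read also stays open.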